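Hydroxymethyl in place of the cyclopropylcarbamoyl on the chain

The source may hold more compounds than are shown below. What is called first, only, known or untested is meant among the compounds shown, and "the series" means these compounds.

Compound 2 `Cn1ncc(Cl)c1-c1cc(C(=O)N[C@@H]2CN[C@H](CC(=O)NC3CC3)C[C@H]2c2ccc(Cl)c(Cl)c2)oc1Cl` and compound 1 `CNC(=O)C[C@@H]1C[C@@H](c2ccc(Cl)c(Cl)c2)[C@H](NC(=O)c2cc(-c3c(Cl)cnn3C)c(Cl)o2)CN1` differ only on an amide-type nitrogen. In an assay for inhibition of RAC-alpha serine/threonine-protein kinase (Homo sapiens), read by HTRF, with a stated time of 1 h (a higher number here means a weaker inhibitor, a lower number a stronger inhibitor), compound 1 gives 2.64 nM, and in this assay compound 2 gives 3.95 nM; the two lie within the scatter, as a 1.5-fold higher number from compound 1 to compound 2 (0.17 log units; within the scatter) shows. Compound 3 `Cn1ncc(Cl)c1-c1cc(C(=O)N[C@@H]2CN[C@H](CCO)C[C@H]2c2ccc(Cl)c(Cl)c2)oc1Cl` carries hydroxymethyl in place of cyclopropylcarbamoyl on a saturated chain carbon bound to a saturated ring carbon. Among the measured compounds shown here, the one measured step only altered the substituent on the carbamoyl nitrogen and was within the scatter, whereas compound 3 removes the carbamoyl entirely, so it gives little guidance. A small shift toward a weaker inhibitor is expected, a 1.8-fold higher number from compound 2 to compound 3 (0.25 log units; within the scatter). In this assay compound 3 is estimated at 7 nM, with a range from 2.5 nM to 25 nM.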

Compound 3, half-maximal inhibitory concentration: 2.74 nM
Compound 3: the middle estimate sits 2.6-fold (0.41 log units) above what was measured; the measured number falls inside the stated range.
By their numbers in this assay, from the lowest: compounds 1, 3 and 2 (each within the scatter of the next).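

Replacing the whole carbamoyl with hydroxymethyl on this saturated chain carbon leaves the number in this assay within the scatter for both amides, with cyclopropylcarbamoyl (a 1.4-fold lower number from compound 2 to compound 3 (0.16 log units; within the scatter)) and with methylcarbamoyl (a 1.0-fold higher number from compound 1 to compound 3 (0.02 log units; within the scatter)). The earlier step changed only the group on the amide-type nitrogen, whereas these steps show that the carbamoyl itself can be absent without a step beyond the scatter. No evidence is available to account for this result. Going by these compounds, whether an amine, a carboxylic acid or a longer chain at this position would stay within the scatter remains open.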